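A few compounds are considered here, and "the series" means these few. Any claim that something is new, unique, unknown or untested is made for them only; others in the source may bear on it.

Measured compounds:
- compound 1, `Cc1cc(NC(=O)Cn2cc(-c3ccc(C#N)cc3)nn2)no1`, gives 9320 nM in a functional assay on BMDM cells (Mus musculus, strain C57BL/6) for inhibition, with a stated time of 2 days; on this read-out higher numbers stand for weaker inhibition and lower numbers for stronger inhibition.
- compound 3, `N#Cc1ccc(-c2cn(CC(=O)Nc3nccs3)nn2)cc1`, gives 270 nM in this assay.
- compound 2, `Cc1cc(NC(=O)Cn2cc(-c3cccc(Cl)c3)nn2)no1`, reaches only a limit of the assay, > 30000 nM, in this assay.

The one counted step among these three runs from compound 1 to compound 3: a 35-fold lower number from compound 1 to compound 3 (1.54 log units; beyond the scatter). The change behind it is 1,3-thiazol-2-yl in place of 5-methyl-1,2-oxazol-3-yl on an amide-type nitrogen. How the core of compound 1 and the core of compound 2 differ is not broken down here. For compound 2 itself the assay reports only a limit, (the limit of > 30000 nM in this assay, at which 1 of the 3 values shown sits), so its true number is not known.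

Compound 4, `O=C(Cn1cc(-c2cccc(Cl)c2)nn1)Nc1nccs1`, has not yet been measured in this assay. It stands to compound 2 as compound 3 stands to compound 1, through (1,3-thiazol-2-yl in place of 5-methyl-1,2-oxazol-3-yl on an amide-type nitrogen), and the place of the change is the same in both pairs. Because the measured step of a 35-fold lower number from compound 1 to compound 3 (1.54 log units; beyond the scatter) is large and well beyond the usual scatter, the same change is expected to lower the number for compound 4 as well; since compound 2 gives only a limit, the starting point is uncertain, and the estimate is wide. The step from compound 2 to compound 4 is expected to be about an at least 10-fold lower number from compound 2 to compound 4 (1.00 log units; beyond the scatter). Compound 4 is thus estimated at 3000 nM, with a likely range from 600 nM to 20000 nM.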

Compound 4, half-maximal inhibitory concentration: > 30000 nM
Compound 4: no number, only a limit (the forecaster's own chance of this, stated with the estimate: 25%); middle value at least 10-fold (1.00 log units) away from the limit.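

Compound 4 reaches only a limit of this assay, > 30000 nM, as compound 2 does, so no step from compound 2 to compound 4 can be read: the limit of > 30000 nM in this assay, at which 2 of the 4 values shown sit.

The compounds shown leave open whether 1,3-thiazol-2-yl in place of 5-methyl-1,2-oxazol-3-yl changes the number with the core of compound 2 as it does with the core of compound 1, and what the true numbers of compound 2 and compound 4 are.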